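The compounds below may be only part of what the source reports. "The series", "measured", "known", "first", "only" and "open" are said of these compounds alone.

Compounds measured in a functional assay on MCF7 cells (Homo sapiens) for inhibition, read by MTT assay, with a stated time of 24 h; on this read-out higher numbers stand for weaker inhibition and lower numbers for stronger inhibition:
- compound 1, `CCOC(=O)C1=Cc2ccccc2OC1(OCc1cn(-c2ccc(C)cc2)nn1)C(F)(F)F`: 26700 nM
- compound 2, `CCOC(=O)C1=Cc2ccccc2OC1(OCc1cn(CC(=O)Nc2ccccc2Br)nn1)C(F)(F)F`: a limit of the assay, > 150000 nM
- compound 3, `CCOC(=O)C1=Cc2ccccc2OC1(OCc1cn(-c2ccc(F)c([N+](=O)[O-])c2)nn1)C(F)(F)F`: 16200 nM

Compound 3 gives the lowest of the two numbers in this assay; compound 1 is nearest, with a 1.6-fold lower number from compound 1 to compound 3 (0.22 log units; within the scatter) separating them. Compound 4, `CCOC(=O)C1=Cc2ccccc2OC1(OCc1cn(CC(=O)NC2CCCCC2)nn1)C(F)(F)F`, has not yet been measured. It differs from compound 3 by (cyclohexylcarbamoyl)methyl in place of 4-fluoro-3-nitrophenyl on an aromatic nitrogen. For the measured compounds named here, two measured steps bear on this change, both of which exchange an aryl group on the aromatic nitrogen for a carbamoylmethyl group or the reverse: an at least 5.6-fold higher number from compound 1 to compound 2 (0.74 log units; beyond the scatter) and an at least 9.2-fold lower number from compound 2 to compound 3 (0.96 log units; beyond the scatter). Both point to a markedly higher number for the carbamoylmethyl type, and the value of compound 2 is only known as a limit (the limit of > 150000 nM in this assay, at which 1 of the 3 values shown sits). Compound 4 is therefore expected to show a 7.4-fold higher number from compound 3 to compound 4 (0.87 log units; beyond the scatter), with an estimate of 120000 nM, between 40000 nM and 300000 nM.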

Compound 4, half-maximal inhibitory concentration: 12100 nM
Compound 4: middle estimate off by 9.9-fold (1.00 log units), on the high side; the whole stated range lies above it.
By their numbers in this assay, from the lowest: compounds 4, 3 and 1 (each within the scatter of the next, the first and the last beyond it). At a limit, above all of these: compound 2.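

In this assay, (cyclohexylcarbamoyl)methyl on the aromatic nitrogen gives a 1.3-fold lower number from compound 3 to compound 4 (0.13 log units; within the scatter) and a 2.2-fold lower number from compound 1 to compound 4 (0.34 log units; beyond the scatter), so this position accepts a carbamoylmethyl group as well as an aryl group. With cyclohexyl in place of 2-bromophenyl on the amide-type nitrogen, the step is an at least 12-fold lower number from compound 2 to compound 4 (1.09 log units; beyond the scatter), so the carbamoylmethyl type as such does not bring the high number of compound 2. The value of compound 2 is a limit: the limit of > 150000 nM in this assay, at which 1 of the 4 values shown sits.

The compounds shown leave open how an unsubstituted phenyl or an open butyl chain on the amide-type nitrogen would read. They also leave open whether a carboxylic acid or an amine on that group would be accepted.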